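The compounds below may be only part of what the source reports. "The series", "measured", "known", "first", "only" and "open" are said of these compounds alone.

Working notes on the series.

Compound 1 `O=C(O)c1cc(-c2cccc(COc3ccc4c(c3)CN(C3CCCC3)C4=O)c2)ccc1O` is read in an ADME assay on microsomes from liver (Rattus norvegicus) for metabolic stability, read by LC-MS, with a stated time of 1 h, at 37 degrees C, tested at 4 uM (on this read-out higher numbers stand for a more stable compound and lower numbers for a less stable compound), where compound 1 gives 9%. This is the lowest of the three numbers in hand: compound 2 `CN(C)C(=O)c1cc(-c2cccc(COc3ccc4c(=O)n(C5CCCC5)sc4c3)c2)ccc1Cl` gives 92% in this assay and compound 3 `CC(C)CCn1sc2cc(OCc3cccc(-c4ccc(Cl)c(C(=O)O)c4)c3)ccc2c1=O` gives 92%, both well beyond the scatter above compound 1, and both carrying a different core from compound 1. Among the compounds with values here, no step between two measured compounds that differ in one place is available, so the move to compound 4 `O=C1c2ccc(OCc3cccc(-c4ccccc4)c3)cc2CN1C1CCCC1` is judged from the whole set rather than from a matched pair.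

Compound 4 differs from compound 1 by phenyl in place of 3-carboxy-4-hydroxyphenyl on an aromatic carbon. The shared core of compound 1 is kept, and the 3-carboxy-4-hydroxyphenyl is exchanged for plain phenyl, which removes both hydrogen-bond donors and both acceptors of that group.

Within the data shown here, the expectation for compound 4 in this assay is a step upward from compound 1 of a number 31 percentage points higher from compound 1 to compound 4 (beyond the scatter), beyond the scatter but not reaching compounds 2 and 3, since the only compound with the core of compound 4 is compound 1 at 9%. Compound 4 is estimated at 40%, within a range from 10% to 75%.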

Compound 4, percent of the compound remaining: 38%
The estimate for compound 4 lay 2 percentage points above the measured number; the measured number falls inside the stated range.
By their numbers in this assay, from the lowest: compound 1; then compound 4; then compounds 2 and 3 (each within the scatter of the next).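

Read in this assay the exchange of 3-carboxy-4-hydroxyphenyl for plain phenyl on the shared core gives a number 29 percentage points higher from compound 1 to compound 4 (beyond the scatter) and provides the first evidence, from a change in one place, that the number responds to the group at this aromatic position. The change removes the carboxylic acid and the hydroxyl together, along with both hydrogen-bond donors and both acceptors of the leaving group, and the step cannot be assigned to any one of these alone. No measurement in hand bears on why the number moves.

Open, on these data alone, is whether phenyl carrying only the carboxylic acid or only the hydroxyl, or carrying an amine or a nitrile instead, would read nearer to compound 1 or to compound 4. Also open, as far as these compounds go, is whether the same exchange would give a step of like size on the core of compound 3.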